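This account rests on a few compounds, and the source may have more. Where it says the series, first, only, none or still open, it means among the compounds named here.

Values in an ADME assay on LL24 cells (Homo sapiens) for inhibition, read by MTT assay, with a stated time of 24 h; on this read-out lower numbers stand for stronger inhibition and higher numbers for weaker inhibition:

- Compound 1 `CC(C)(C)c1ccc(C(=O)N/N=C/c2ccc([N+](=O)[O-])o2)cc1`: > 200000 nM
- Compound 2 `O=C(N/N=C/c1ccc([N+](=O)[O-])o1)C1CCCCC1`: > 200000 nM
- Compound 3 `CCCCOc1ccc(C(=O)N/N=C/c2ccc([N+](=O)[O-])o2)cc1`: > 200000 nM

Each of these entries is a limit of the assay and not a number. Together they form a simple picture: the limit of > 200000 nM in this assay, at which 3 of the 3 values shown sit. Compound 3 therefore has no exact position on the scale, and it cannot be ranked against compound 1 or compound 2.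

The next compound is compound 4 `CCCCNc1ccc(C(=O)N/N=C/c2ccc([N+](=O)[O-])o2)cc1`. It keeps the shared core of compound 3 and makes one change, butylamino in place of butoxy on an aromatic carbon, para to a large group: butylamino in place of butoxy on an aromatic carbon.

Within the data shown here, only one measured step involves a change on this kind of carbon: a step that the two limits leave unreadable from compound 1 to compound 3. Among the measured compounds shown here, it offers no size to carry over, so no step of a known size or direction is expected in this assay. The most likely outcome is that this new compound also reaches the limit, although a measurable number remains possible. The estimated step is a number no higher from compound 3 to compound 4 (the limit leaves the size open). The expected value for compound 4 is 200000 nM, with an estimated range from 70000 nM to 400000 nM.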

Compound 4, half-maximal inhibitory concentration: 47000 nM
Compound 4: middle estimate off by 4.3-fold (0.63 log units), on the high side, and the stated range ends above it.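

In this assay, among these compounds, putting butylamino in place of butoxy on this aromatic carbon gives an at least 4.2-fold lower number from compound 3 to compound 4 (0.62 log units; beyond the scatter), the first step at this position with a readable size, as the earlier step here cannot be read. Putting butylamino in place of tert-butyl on the same carbon gives an at least 4.2-fold lower number from compound 1 to compound 4 (0.62 log units; beyond the scatter), so a measurable number appears with this one group and with neither of the other two groups tried at this carbon. Butoxy and butylamino have the same count of heavy atoms and differ in oxygen against nitrogen and in the hydrogen-bond donor that butylamino adds, yet only compound 4 leaves the ceiling of the assay, where the other compounds remain: the limit of > 200000 nM in this assay, at which 3 of the 4 values shown sit.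

On these data alone, the true size of both steps stays open, as each starts from a limit and not from a number. As far as these compounds go, it is also open whether the hydrogen on the nitrogen matters or whether the chain length does, which a dibutylamino group, with no such hydrogen, or a shorter ethylamino chain could help to separate.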